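A Ring Swap and a Number Still to Come

The compounds below may be only part of what the source reports. "The series", "measured", "known", "first", "only" and "open" are said of these compounds alone.

Of the compounds shown here, three sharing a core have been measured so far. In a physicochemical assay for lipophilicity, read by HPLC, in phosphate buffer, measured as octanol-water partition, at pH 7.4, tested at 100 uM (on this read-out higher numbers stand for higher lipophilicity and lower numbers for lower lipophilicity), compound 3 (`O=C(O)COc1ccc(NCc2cccc(-c3ccccc3Cl)c2)cc1F`) gives 2.71 as its reading. Compound 2 (`O=C(O)COc1ccc(NCc2ccc(Cl)c(-c3ccccc3)c2)cc1F`) gives 2.74 as its reading, within the usual scatter of compound 3, so the two cannot be told apart. Compound 1 (`CCCOc1cc(C)c(-c2cccc(CNc3ccc(OCC(=O)O)c(F)c3)c2)c(C)c1`) reads 3.59 and stands beyond the scatter above both. Compound 3 therefore belongs to the low pair among the three numbers.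

The next compound is compound 4 (`CCOc1ccc(-c2cccc(CNc3ccc(OCC(=O)O)c(F)c3)c2)c(C)c1`), in which 4-ethoxy-2-methylphenyl replaces 2-chlorophenyl on an aromatic carbon, meta to a large group (4-ethoxy-2-methylphenyl in place of 2-chlorophenyl on an aromatic carbon). Going by the values given here, no two measured compounds differ in one place only, so no measured step shows what such a swap does. The closest guide is compound 1, at 3.59 in this assay, whose outer ring also carries an ether chain and methyl substitution. Compound 4 is thus expected to move clearly upward from compound 3 but to stop short of compound 1, whose outer ring carries the larger substitution. The estimated move is upward, a number 0.49 log units higher from compound 3 to compound 4 (beyond the scatter) (beyond the scatter). Compound 4 is expected to read about 3.2 (estimated range 2.85 to 3.55).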

Compound 4, distribution coefficient: 2.83
Compound 4: the middle estimate sits 0.37 log units above what was measured; measured number below the stated range.
By their numbers in this assay, from the lowest: compounds 3, 2 and 4 (each within the scatter of the next); then compound 1.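

At this position, on an aromatic carbon meta to a large group, the series now has its first reading of a single change: in this assay, putting 4-ethoxy-2-methylphenyl in place of 2-chlorophenyl gives a number 0.12 log units higher from compound 3 to compound 4 (within the scatter) as the step, so the two compounds cannot be told apart. The entering group has 10 heavy atoms against 7 and one hydrogen-bond acceptor against none, and it holds an oxygen where the leaving group held a chlorine, yet for this one pair these differences do not carry the reading beyond the usual scatter. Nothing available here accounts for how close the two readings lie.

This single pair cannot show whether the same holds for other groups at this place, such as a longer chain on the outer ring, an amine or a nitrile. It also leaves open which part of the swap matters, since the ethoxy group, the methyl group and the loss of chlorine all change together and no compound shown separates them.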